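Working notes: from compound 2 to compound 4

The source may hold more compounds than are shown below. What is called first, only, known or untested is meant among the compounds shown, and "the series" means these compounds.

In an ADME assay on HEK293 cells (Homo sapiens) for antiproliferative activity, read by MTT assay (on this read-out higher numbers stand for weaker inhibition and lower numbers for stronger inhibition), compound 1 (`Nc1c(C(=O)N/N=C/c2ccccc2)oc2nc(-c3ccccc3)cc(C(F)(F)F)c12`) gives 70000 nM, compound 2 (`Nc1c(C(=O)N/N=C/c2ccc(Cl)cc2)oc2nc(-c3cccs3)cc(C(F)(F)F)c12`) gives 83000 nM and compound 3 (`Nc1c(C(=O)N/N=C/c2ccc(Cl)cc2)oc2nc(-c3ccccc3)cc(C(F)(F)F)c12`) gives 81000 nM, so compound 2 stands within the scatter of both others. The change to compound 4 (`CCCNC(=O)c1oc2nc(-c3cccs3)cc(C(F)(F)F)c2c1N`) is a group of 3 heavy atoms (3 carbon; no ring) in place of a group of 9 heavy atoms (7 carbon, 1 nitrogen, 1 chlorine; one six-membered aromatic ring of carbon only), on an amide-type nitrogen. Going by the values given here, two measured steps offer the only guidance: a 1.2-fold higher number from compound 1 to compound 3 (0.06 log units; within the scatter), with chloro in place of hydrogen, and a 1.0-fold lower number from compound 2 to compound 3 (0.01 log units; within the scatter), with phenyl in place of thiophen-2-yl. Both are small, but neither replaces the group that leaves here, so no direct measure of this change exists. The expected change is a 1.2-fold lower number from compound 2 to compound 4 (0.07 log units; within the scatter), with no shift beyond the scatter expected in this assay. For compound 4 the estimated value is 70000 nM, with an expected range of 25000 nM to 160000 nM.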

Compound 4, half-maximal inhibitory concentration: 64000 nM
Compound 4: middle estimate off by 1.1-fold (0.04 log units), on the high side; the measured number falls inside the stated range.
By their numbers in this assay, from the lowest: compounds 4, 1, 3 and 2 (each within the scatter of the next).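

In this assay, propyl in place of the group of 9 heavy atoms on the amide-type nitrogen gives a 1.3-fold lower number from compound 2 to compound 4 (0.11 log units; within the scatter) and so stays within the scatter. This position therefore tolerates the loss of the six-membered aromatic ring and the double bond outside it, a larger structural change than either earlier single-place step, with no shift beyond the scatter. No measurement available here bears on the reason for this result. Still open, from the compounds shown here alone, is whether a longer chain, an amine or a carboxylic acid on this nitrogen would move the number beyond the scatter.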